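Cytotoxicity in HEL Cells: Carbamoyl Versus Carbamoylcarbonylmethyl

The source may report more compounds than this note shows. Statements on the series, on what has been measured and on what is new or still open speak of the compounds shown alone.

Measured so far:
Compound 1, `Cc1cn([C@@H]2O[C@H](CO[Si](C)(C)C(C)(C)C)[C@@]3(OS(=O)(=O)C=C3NCC(=O)C(=O)N3CCC3)[C@H]2O[Si](C)(C)C(C)(C)C)c(=O)n(C)c1=O`: in a functional assay on HEL cells (Homo sapiens) for cytotoxicity, read by microscopy (a lower number here means that less compound is tolerated, a higher number that more compound is tolerated), compound 1 gives 65000 nM.
Compound 2, `Cc1cn([C@@H]2O[C@H](CO[Si](C)(C)C(C)(C)C)[C@@]3(OS(=O)(=O)C=C3NC(N)=O)[C@H]2O[Si](C)(C)C(C)(C)C)c(=O)n(C)c1=O`: in this assay compound 2 gives 16000 nM.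

Among the measured compounds shown here, compound 2 stands at the lowest of the two numbers, so it is the less tolerated of the pair; the only step known, a 4.1-fold lower number from compound 1 to compound 2 (0.61 log units; beyond the scatter), separates it from compound 1. Compound 3, `Cc1cn([C@@H]2O[C@H](CO[Si](C)(C)C(C)(C)C)[C@@]3(OS(=O)(=O)C=C3NCC(=O)C(N)=O)[C@H]2O[Si](C)(C)C(C)(C)C)c(=O)n(C)c1=O`, has not yet been measured in this assay. It differs from compound 2 in one place: (carbamoylcarbonyl)methyl in place of carbamoyl on an amine nitrogen. For the measured compounds named here, that change bears a partial resemblance to the one measured step, since the group that enters in compound 3 shares the methyl-carbonyl arrangement of the group that left on the way from compound 1 to compound 2, while keeping the terminal carbamoyl of compound 2. The step from compound 1 to compound 2 was modest but beyond the scatter, and it ran downward. The change from compound 2 to compound 3 is expected to run partly back in the opposite direction, with a step of a 2.2-fold higher number from compound 2 to compound 3 (0.34 log units; beyond the scatter) in this assay. Compound 3 is therefore estimated at 35000 nM, within a range from 15000 nM to 90000 nM.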

Compound 3, minimum cytotoxic concentration: >= 16000 nM
Compound 3: only a limit was reported; the forecaster's own chance of this, stated with the estimate: 10%; the middle value lies beyond the limit too.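

In this assay compound 3 returned only a limit and not a number: the limit of >= 16000 nM in this assay, at which 1 of the 3 values shown sits. Even so, this gives a direction for the change on the amine nitrogen, with a number no lower from compound 2 to compound 3 (the limit leaves the size open), so placing (carbamoylcarbonyl)methyl there in place of carbamoyl did not bring the number under that of the ureido compound. The size of that step cannot be read, and neither can the step between the compounds that differ by azetidin-1-yl and amino on a carbonyl carbon, so the result does not show whether the new group recovers all, part or none of what separated the two earlier compounds.

As far as these compounds go, it remains open how far the true number of compound 3 lies from those of compound 1 and compound 2, and therefore whether azetidin-1-yl and amino on that carbonyl carbon differ at all in this assay. Also open, from the compounds shown here alone, is what a dimethylamino group or a hydroxyl, giving a carboxylic acid, on that carbonyl carbon would do to the number, or a longer chain on the amine nitrogen.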